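Linker length and hydroxyl capping in the amide side chain

The compounds below may be only part of what the source reports. "The series", "measured", "known", "first", "only" and "open" are said of these compounds alone.

Compound 3 `C[C@@H](O)CCNC(C)(C)C(=O)N[C@@H]1CCc2ccccc2N(Cc2ccc(-c3ccccc3-c3nn[nH]n3)cc2)C1=O` gives 100 nM in a functional assay (Pituitary gland cell) with Rattus norvegicus as the target (on this read-out higher numbers stand for an effect only at larger amounts of compound and lower numbers for an effect already at smaller amounts), the second highest of the three numbers measured. Compound 1 `C[C@@H](O)CCNC(C)(C)CC(=O)N[C@@H]1CCc2ccccc2N(Cc2ccc(-c3ccccc3-c3nn[nH]n3)cc2)C1=O` gives 10 nM in this assay, and compound 2 `C[C@@H](O)CNC(C)(C)C(=O)N[C@@H]1CCc2ccccc2N(Cc2ccc(-c3ccccc3-c3nn[nH]n3)cc2)C1=O` gives 300 nM. The steps are a 10-fold higher number from compound 1 to compound 3 (1.00 log units; beyond the scatter), a 30-fold higher number from compound 1 to compound 2 (1.48 log units; beyond the scatter) and a 3.0-fold lower number from compound 2 to compound 3 (0.48 log units; beyond the scatter).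

Compound 4 `CO[C@H](C)CNC(C)(C)CC(=O)N[C@@H]1CCc2ccccc2N(Cc2ccc(-c3ccccc3-c3nn[nH]n3)cc2)C1=O` differs from compound 3 in one place: 2-((2-methoxypropyl)amino)-2-methylpropyl in place of 1-((3-hydroxybutyl)amino)-1-methylethyl on a carbonyl carbon. Going by the values given here, two measured steps bear on it. The longer propyl spacer to the carbonyl is the feature of compound 1, and the step of a 10-fold higher number from compound 1 to compound 3 (1.00 log units; beyond the scatter) shows its removal costs a lot; restoring it should help compound 4. The shortening from 3-hydroxybutyl to a three-carbon chain matches the step of a 3.0-fold lower number from compound 2 to compound 3 (0.48 log units; beyond the scatter) run in reverse, which would cost a little. Capping the hydroxyl as a methyl ether has no measured counterpart here. Net, compound 4 is expected to sit between compound 3 and compound 1, giving an estimated 40 nM, with a range from 10 nM to 300 nM; the expected step is a 2.5-fold lower number from compound 3 to compound 4 (0.40 log units; beyond the scatter).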

Compound 4, concentration for half-maximal effect: 20 nM
Beside the measured number, compound 4's estimate is 2.0-fold (0.30 log units) above it; low and high end bracket the measured number.
By their numbers in this assay, from the lowest: compounds 1 and 4 (each within the scatter of the next); then compound 3; then compound 2.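

Compound 4 extends the spacer finding to a chain capped as a methyl ether: with 2-((2-methoxypropyl)amino)-2-methylpropyl on the carbonyl carbon, a 5.0-fold lower number from compound 3 to compound 4 (0.70 log units; beyond the scatter) and a 15-fold lower number from compound 2 to compound 4 (1.18 log units; beyond the scatter) in this assay. Going by these compounds alone, in all four compounds, the two carrying the 2-methylpropyl linkage have lower numbers than the two carrying the 1-methylethyl linkage, with no compound going against this. Replacing 2-hydroxypropyl with 1-methoxyethyl on a saturated chain carbon bound to an amine nitrogen gives a 2.0-fold higher number from compound 1 to compound 4 (0.30 log units; within the scatter), so on this longer linkage a free hydroxyl is not required to keep the number low, and no evidence on hand accounts for these differences.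

Compound 1 and compound 4 differ in both chain length and capping, so the contribution of each remains unresolved. Also open, going by these compounds, is how an ethoxy group, a primary amine or a carboxylic acid at the chain end would read out on this linkage.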